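The source may report more compounds than this note shows. Statements on the series, on what has been measured and on what is new or still open speak of the compounds shown alone.

Compound 1 `COc1ccc(-c2cc(=O)oc3ccccc23)cc1O` gives 96 nM in a functional assay on K562 cells (Homo sapiens) for cytotoxicity, read by MTT assay, with a stated time of 48 h; on this read-out lower numbers stand for stronger inhibition and higher numbers for weaker inhibition. Compound 2 `COc1ccc(-c2cc(=O)oc3cccc(OC)c23)cc1O` gives 86 nM in this assay.

On these two numbers compound 2 sits within the scatter of compound 1: a 1.1-fold lower number from compound 1 to compound 2 (0.05 log units; within the scatter). Compound 3 `COc1cc(OC)c2c(-c3ccc(OC)c(O)c3)cc(=O)oc2c1` carries one further change, (methoxy in place of hydrogen on an aromatic carbon). Among the compounds with values here, the single measured step that bears on it, from compound 1 to compound 2, was itself a methoxy in place of hydrogen on an aromatic carbon and stayed within the scatter, so no step beyond the scatter is expected for this assay here either; the estimated step is a 1.1-fold lower number from compound 2 to compound 3 (0.03 log units; within the scatter). Compound 3 is therefore expected to give about 80 nM, with a likely range from 40 nM to 170 nM.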

Compound 3, half-maximal inhibitory concentration: 100 nM
For compound 3 the middle estimate is 1.3-fold (0.10 log units) below the measured one; low and high end bracket the measured number.
By their numbers in this assay, from the lowest: compounds 2, 1 and 3 (each within the scatter of the next).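

At this position, on the aromatic carbon meta to a methoxy group, the methoxy in place of hydrogen also stayed within the scatter in this assay, with a 1.2-fold higher number from compound 2 to compound 3 (0.07 log units; within the scatter). The ring of the core that carries this position has now taken a methoxy at two different carbons, the earlier one in the step with a 1.1-fold lower number from compound 1 to compound 2 (0.05 log units; within the scatter), and neither step left the scatter. Nothing available accounts for this result. On these data alone, whether an amine, a carboxylic acid or a longer chain such as butoxy at this carbon would also stay within the scatter remains open.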